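This account rests on a few compounds, and the source may have more. Where it says the series, first, only, none or still open, it means among the compounds named here.

Compound 1 `Cc1cn(C2CC(O)C(C(=O)Nc3ccc(C(=O)CI)cc3)O2)c(=O)[nH]c1=O`: 13 h
Compound 2 `Cc1cn(C2CC(O)C(CCC(=O)CI)O2)c(=O)[nH]c1=O`: 4 h
Compound 3 `Cc1cn(C2CC(O)C(C(=O)Nc3ccc(C(=O)CCl)cc3)O2)c(=O)[nH]c1=O`: a limit of the assay, > 52 h

In an ADME assay for pharmacokinetics (on this read-out lower numbers stand for a shorter-lived compound and higher numbers for a longer-lived compound), compound 3 stands at a limit of the assay, > 52 h, not at a number. Compound 4 `Cc1cn(C2CC(O)C(C(=O)Nc3ccc(C(=O)CBr)cc3)O2)c(=O)[nH]c1=O` differs from it by bromo in place of chloro on a saturated chain carbon bound to a carbonyl carbon. Among the measured compounds shown here, the one measured step at this position is an at least 4.0-fold higher number from compound 1 to compound 3 (0.60 log units; beyond the scatter). Bromo sits between chloro and iodo in the halogen series, so the change to compound 4 runs part of the way back toward compound 1; the expected step is an at least 2.0-fold lower number from compound 3 to compound 4 (0.30 log units; that floor lies within the scatter), a shorter half-life than compound 3 shows, but not as short as compound 1 at 13 h. Compound 4 is therefore estimated at 26 h, with a range from 11 h to 55 h.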

Compound 4, half-life: 4 h
Beside the measured number, compound 4's estimate is 6.5-fold (0.81 log units) above it, and the stated range ends above it.
By their numbers in this assay, from the lowest: compounds 2 and 4 (each within the scatter of the next); then compound 1. At a limit, above all of these: compound 3.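

In this assay, the halogen on a saturated chain carbon bound to a carbonyl carbon does not give a steady trend. Bromo in place of chloro gives an at least 13-fold lower number from compound 3 to compound 4 (1.11 log units; beyond the scatter), and bromo in place of iodo gives a 3.3-fold lower number from compound 1 to compound 4 (0.51 log units; beyond the scatter), so the bromo compound, not the iodo one, is lowest of these three. The first step is only a floor, since compound 3 stands at a limit of the assay: the limit of > 52 h in this assay, at which 1 of the 4 values shown sits.

The compounds shown leave open how fluoro, or an amine, would behave at this place. From the compounds shown here alone, whether this order holds on the core of compound 2, which carries only iodo, also stays open.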